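The compounds below may be only part of what the source reports. "The series", "measured", "known", "first", "only" and "open" are said of these compounds alone.

Compound 1 `COCCOc1cc2ncnc(Nc3cccc(B(O)O)c3)c2cc1OCCOC`: > 1000 nM
Compound 2 `COc1cc2ncnc(Nc3cccc(B(O)O)c3)c2cc1OC`: > 1000 nM

In an assay on isolated protein for inhibition of vascular endothelial growth factor receptor 1 (Homo sapiens), read by ELISA, with a stated time of 20 min (on this read-out higher numbers stand for weaker inhibition and lower numbers for stronger inhibition), compound 2 gives > 1000 nM, which is a limit of the assay and not a number. Compound 1 likewise gives only a limit in this assay, > 1000 nM. Going by the values given here, both measured values therefore sit at the limit of > 1000 nM in this assay, at which 2 of the 2 values shown sit, so no step between measured compounds can be read. Compound 3 `COCCOc1cc2ncnc(Nc3cccc(B(O)O)c3)c2cc1OC` differs from compound 2 by methoxymethyl in place of hydrogen on a saturated chain carbon bound to an oxygen on an aromatic ring. Since both compounds sit at the limit, a step that the limit leaves unreadable from compound 2 to compound 3 is expected, none beyond the scatter. Compound 3 is expected at 3000 nM, within 800 nM to 20000 nM, most likely again reported only as a limit.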

Compound 3, half-maximal inhibitory concentration: > 1000 nM
Compound 3: a limit, no number (the forecaster's own chance of this, stated with the estimate: 85%); the middle value does not contradict the limit.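

No step can be read among compound 1, compound 2 and compound 3 in this assay, since each gives only a limit: the limit of > 1000 nM in this assay, at which 3 of the 3 values shown sit. The compounds shown leave open whether methoxymethyl in place of hydrogen changes inhibition at all, as none of the three has a true number.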